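Morpholin-4-yl in Place of Piperidin-1-yl on the Carbonyl

The source may report more compounds than this note shows. Statements on the series, on what has been measured and on what is new or still open speak of the compounds shown alone.

Three compounds sharing one core differ only in the ring attached to the carbonyl carbon. In a functional assay on the whole organism with Mus musculus as the target, in the elevated plus maze, with a stated time of 24 h, at a dose of 1 mg/kg by the intraperitoneal route (a higher number here means a stronger effect of the compound at the dose given, a lower number a weaker effect), compound 1 `CN1CCN(C(=O)COc2cccc3ccccc23)CC1` gives 73.8%, compound 2 `O=C(COc1cccc2ccccc12)N1CCCC1` gives 51.6%, and compound 3 `O=C(COc1cccc2ccccc12)N1CCCCC1` gives 63%. Compound 3 thus stands second of the three, set by the steps of a number 10.8 percentage points lower from compound 1 to compound 3 (beyond the scatter) and a number 11.4 percentage points higher from compound 2 to compound 3 (beyond the scatter). Compound 4 `O=C(COc1cccc2ccccc12)N1CCOCC1` is not yet measured; it differs from compound 3 in one place: morpholin-4-yl in place of piperidin-1-yl on a carbonyl carbon. For the measured compounds named here, the steps that bear on this change are a number 22.2 percentage points lower from compound 1 to compound 2 (beyond the scatter), a number 10.8 percentage points lower from compound 1 to compound 3 (beyond the scatter) and a number 11.4 percentage points higher from compound 2 to compound 3 (beyond the scatter), all modest, so a modest step is expected here as well, while its direction cannot be read from them. For compound 4 the expected step is a number 5 percentage points lower from compound 3 to compound 4 (within the scatter), giving an estimate of 58% with a range from 40% to 75%.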

Compound 4, a percentage reported as activity, at one dose (the size of the read-out at that dose, not a potency): 62.7%
Beside the measured number, compound 4's estimate is 4.7 percentage points below it; the range from low to high includes it.
By their numbers in this assay, from the lowest: compound 2; then compounds 4 and 3 (each within the scatter of the next); then compound 1.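

In this assay the change on the carbonyl carbon from piperidin-1-yl to morpholin-4-yl gives a number 0.3 percentage points lower from compound 3 to compound 4 (within the scatter), so the extra ring hetero atom and hydrogen-bond acceptor do not separate these two six-membered rings at this dose. Compound 4 also sits clear of the other two rings, with a number 11.1 percentage points higher from compound 2 to compound 4 (beyond the scatter) and a number 11.1 percentage points lower from compound 1 to compound 4 (beyond the scatter), much as compound 3 does. Nothing available explains these results. Going by these compounds, it remains open whether an open-chain diethylamino group or the seven-membered azepan-1-yl ring would fit this picture. A single dose also shows only which compounds have a stronger or weaker effect at that dose.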